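A Heteroaryl Swap on a Shared Core: Compound 2 to Compound 4

This account rests on a few compounds, and the source may have more. Where it says the series, first, only, none or still open, it means among the compounds named here.

Of the compounds shown here, three that share one core have been tested in a functional assay on CHO-K1 cells for antagonist activity at adenosine receptor A1 (Homo sapiens), read by a beta-galactosidase reporter and cAMP accumulation, with stated times of 15 min and 6 h; a lower number here means a stronger inhibitor, a higher number a weaker inhibitor. Compound 1 `COc1ccccc1Cc1cc2c(N)nc(-c3ccc(C)o3)nc2s1` gives 122 nM, compound 2 `CCc1ccc(-c2nc(N)c3cc(Cc4ccccc4)sc3n2)o1` gives 223 nM, and compound 3 `Cc1csc(-c2nc(N)c3cc(Cc4ccccc4Cl)sc3n2)n1` gives 49.6 nM. Compound 2 has the highest of the three numbers; its nearest neighbour is compound 1, which lies within the scatter of repeated measurements, while compound 3 sits further off with a lower number, beyond that scatter.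

Compound 4 `Nc1nc(-c2cccc(Cl)n2)nc2sc(Cc3ccccc3)cc12` is not yet measured. It differs from compound 2 in one place: 6-chloropyridin-2-yl in place of 5-ethylfuran-2-yl on an aromatic carbon. The rest of the molecule is kept. Within the data shown here, no measured pair in this set shows exactly this exchange, so its effect is not known from the data. Since compound 1 at 122 nM and compound 2 at 223 nM differ in more than one place yet sit within the scatter of each other, only a modest move in either direction is expected here. Compound 4 is estimated at 180 nM, with a range from 60 nM to 550 nM. This estimate means an expected step of a 1.2-fold lower number from compound 2 to compound 4 (0.09 log units; within the scatter), within the scatter.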

Compound 4, inhibition constant: > 1000 nM
Compound 4 was reported as a limit (the forecaster's own chance of this, stated with the estimate: 5%); middle value at least 5.5-fold (0.74 log units) from the limit.
By their numbers in this assay, from the lowest: compound 3; then compounds 1 and 2 (each within the scatter of the next). At a limit, above all of these: compound 4.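

In this assay, among these compounds, the position between two ring nitrogen atoms proves sensitive to the ring placed on it: 6-chloropyridin-2-yl in place of 5-ethylfuran-2-yl gives an at least 4.4-fold higher number from compound 2 to compound 4 (0.65 log units; beyond the scatter), the first change in this set made in one place only. The two groups have the same heavy-atom count and each carries one hydrogen-bond acceptor, so these counts alone do not decide the outcome at this position. Compound 4 is reported only as a limit of the assay, so the step has a lower bound but no measured size: the limit of > 1000 nM in this assay, at which 1 of the 4 values shown sits.

The compounds shown do not separate the ring exchange from the chlorine, as they include no plain pyridin-2-yl. As far as these compounds go, how a pyridine ring carrying an amine or a methyl group in place of the chlorine would behave also remains open.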